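Formyl to Fluoro on the Sulfonyl Aryl Group

This account rests on a few compounds, and the source may have more. Where it says the series, first, only, none or still open, it means among the compounds named here.

Measured compounds:
- compound 1, `COc1ccc(-c2c(Cl)c(=O)c3c(OC)cc(OC)cc3n2S(=O)(=O)c2ccc(OC)cc2)cc1`: 19100 nM
- compound 2, `COc1ccc(-c2cc(=O)c3c(OC)cc(OC)cc3n2S(=O)(=O)c2ccc(C=O)cc2)cc1`: limit, > 34400 nM

In a functional assay on KOPN-8 cells (Homo sapiens) for antiproliferative activity, with a stated time of 72 h (on this read-out lower numbers stand for an effect already at smaller amounts and higher numbers for an effect only at larger amounts of compound), compound 1 gives 19100 nM. For compound 2 this assay reports only a limit, > 34400 nM, and no number is known. Compound 2 therefore sits at the limit of > 34400 nM in this assay, at which 1 of the 2 values shown sits, so its position relative to compound 1 cannot be stated beyond the fact that no effect was reached within the tested amounts. For the measured compounds named here, the two measured compounds differ in more than one place, so no single step between them is available.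

Compound 3, `COc1ccc(-c2cc(=O)c3c(OC)cc(OC)cc3n2S(=O)(=O)c2ccc(F)cc2)cc1`, differs from compound 2 by fluoro in place of formyl on an aromatic carbon. Nothing measured in this series isolates this change, and the value of compound 2 is a limit, so the size of the step cannot be anchored to a number. The expectation is that the step from compound 2 to compound 3 is modest and within, or close to, the scatter, with the direction uncertain, estimated as an at least 1.3-fold lower number from compound 2 to compound 3 (0.13 log units; that floor lies within the scatter). Compound 3 is estimated at 25000 nM, with an expected range from 8000 nM to 70000 nM, and a sizable chance that this assay again returns only a limit.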

Compound 3, half-maximal effective concentration: > 65500 nM
Compound 3: a limit, no number; the forecaster's own chance of this, stated with the estimate: 45%; middle value at least 2.6-fold (0.41 log units) from the limit.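

In this assay, for the compounds shown here, compound 2 and compound 3 both return only limits, so no step between them can be read. The compounds shown leave open how (4-formylphenyl)sulfonyl and (4-fluorophenyl)sulfonyl compare on the shared core in this read-out.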